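The source may hold more compounds than are shown below. What is called first, only, known or untested is meant among the compounds shown, and "the series" means these compounds.

Working notes on the series. In a functional assay on MCF7 cells (Homo sapiens) for antiproliferative activity, read by MTT assay, with a stated time of 72 h (a higher number here means a weaker inhibitor, a lower number a stronger inhibitor), compound 1 `CCc1ccccc1OS(=O)(=O)C1CC2OC1C(c1ccc(/C=C/c3cc(OC)cc(OC)c3)cc1)=C2c1ccc(O)cc1` gives 49800 nM and compound 2 `Cc1ccccc1OS(=O)(=O)C1CC2OC1C(c1ccc(/C=C/c3cc(O)cc(O)c3)cc1)=C2c1ccc(O)cc1` gives 55800 nM, two values within the scatter of each other. Compound 3 `Cc1ccc(OS(=O)(=O)C2CC3OC2C(c2ccc(/C=C/c4cc(O)cc(O)c4)cc2)=C3c2ccc(O)cc2)cc1` has 4-methylphenyl in place of 2-methylphenyl on an oxygen, the other neighbour of that oxygen being the sulfonyl sulfur (4-methylphenyl in place of 2-methylphenyl on an oxygen). Within the data shown here, no measured pair shows this change, so the expectation starts from compound 2 at 55800 nM, and no effect beyond the scatter is expected in this assay. The estimated step is a 1.2-fold lower number from compound 2 to compound 3 (0.09 log units; within the scatter), with no firm direction. For compound 3 the expected value is 45000 nM, within an estimated range of 20000 nM to 95000 nM.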

Compound 3, half-maximal inhibitory concentration: 9200 nM
Beside the measured number, compound 3's estimate is 4.9-fold (0.69 log units) above it; measured number below the stated range.
By their numbers in this assay, from the lowest: compound 3; then compounds 1 and 2 (each within the scatter of the next).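

In this assay, among these compounds, 4-methylphenyl in place of 2-methylphenyl on the oxygen whose other neighbour is the sulfonyl sulfur gives a 6.1-fold lower number from compound 2 to compound 3 (0.78 log units; beyond the scatter), the only step yet read at this position. The two groups have the same atom counts, so at this position the placement of the methyl group alone separates compound 2 from compound 3. Nothing available accounts for this step.

Open, going by these compounds, is whether 4-ethylphenyl or 4-aminophenyl on the same oxygen would follow 4-methylphenyl. Also open, on these data alone, is whether the step holds with the methoxy groups of compound 1.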